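The source may report more compounds than this note shows. Statements on the series, on what has been measured and on what is new or still open speak of the compounds shown alone.

Measured so far in a functional assay on MCF7 cells (Homo sapiens) for cytotoxicity, read by MTT assay, with a stated time of 48 h; a higher number here means a weaker inhibitor, a lower number a stronger inhibitor:
compound 1, `CNC(=O)CSc1nc2ccc(NC(=O)c3ccccc3)cc2s1` — 34400 nM
compound 2, `CC(=O)Nc1ccc2nc(SCC(=O)NCc3ccccc3)sc2c1` — 17600 nM

Compound 2 holds the lower of the two numbers in this assay. Its nearest neighbour is compound 1, whose value sits within the scatter of that of compound 2, so no order between the two can be read from this assay.

Compound 3, `O=C(CSc1nc2ccc(NC(=O)c3ccccc3)cc2s1)NCc1ccccc1`, is not yet measured in this assay. It differs from compound 2 in one place: phenyl in place of methyl on a carbonyl carbon. Compound 1 already carries the benzamido group, though with a different amide on the other side, and its value stays within the scatter of compound 2. For the measured compounds named here, no pair of measured compounds differs only in this place, so the expectation rests on those two numbers alone. The expected step is a 1.1-fold higher number from compound 2 to compound 3 (0.06 log units; within the scatter), nothing beyond the scatter. Compound 3 is therefore estimated at 20000 nM, with a range of 8000 nM to 50000 nM.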

Compound 3, half-maximal inhibitory concentration: 35600 nM
For compound 3 the middle estimate is 1.8-fold (0.25 log units) below the measured one, and the stated range covers the measured number.
By their numbers in this assay, from the lowest: compounds 2, 1 and 3 (each within the scatter of the next, the first and the last beyond it).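

In this assay, for the compounds shown here, acetamido to benzamido on the shared core gives a 2.0-fold higher number from compound 2 to compound 3 (0.31 log units; beyond the scatter), a modest step and the first single change to pass the scatter, so this carbonyl carbon is a place where the group can register, though only just. With benzamido held fixed, phenyl in place of hydrogen on a saturated chain carbon bound to an amide-type nitrogen gives a 1.0-fold higher number from compound 1 to compound 3 (0.01 log units; within the scatter), so that change registers nothing in this assay. No measurement at hand bears on the reason for either step.

On these data alone, only methyl and phenyl appear on this carbonyl carbon, so a longer chain or a chain carrying an amine remains open there. As far as these compounds go, whether the acetamido to benzamido step would read the same with the amide of compound 1 also remains open.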